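Replacing benzoyl with ethylcarbamoyl on a sulfonamide scaffold

This account rests on a few compounds, and the source may have more. Where it says the series, first, only, none or still open, it means among the compounds named here.

Measured compounds:
compound 1, `O=C(Nc1ccc(S(=O)(=O)Nc2cc(F)c(O)c(F)c2)cc1)c1ccccc1`, 68600 nM
compound 2, `Nc1ccc(S(=O)(=O)N(Cc2ccc(Br)cc2F)c2cc(F)c(O)c(F)c2)cc1`, 73100 nM

Of the compounds shown here, two have been measured in a functional assay for inhibition; a lower number here means a stronger inhibitor, a higher number a weaker inhibitor. Compound 1, `O=C(Nc1ccc(S(=O)(=O)Nc2cc(F)c(O)c(F)c2)cc1)c1ccccc1`, gives 68600 nM in this assay. Compound 2, `Nc1ccc(S(=O)(=O)N(Cc2ccc(Br)cc2F)c2cc(F)c(O)c(F)c2)cc1`, gives 73100 nM. The two numbers sit within the usual scatter of each other, so neither can be called the stronger inhibitor; both are weak on this scale.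

Compound 3, `CCNC(=O)Nc1ccc(S(=O)(=O)Nc2cc(F)c(O)c(F)c2)cc1`, has not been measured. It shares the core of compound 1 and differs from it in one place: ethylamino in place of phenyl on a carbonyl carbon. Read one bond further out, a benzamido group becomes an (ethylcarbamoyl)amino group.

Among the measured compounds shown here, no pair of measured compounds differing in one place has been recorded, so there is no measured step to lean on. With both measured compounds so weak and the change touching only the amide end, no step beyond the scatter is expected; the estimated step from compound 1 to compound 3 is a 1.2-fold higher number from compound 1 to compound 3 (0.07 log units; within the scatter). Compound 3 is therefore expected to give about 80000 nM in this assay, in a range from 25000 nM to 250000 nM.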

Compound 3, half-maximal inhibitory concentration: 81700 nM
Beside the measured number, compound 3's estimate is 1.0-fold (0.01 log units) below it, and the stated range covers the measured number.
By their numbers in this assay, from the lowest: compounds 1, 2 and 3 (each within the scatter of the next).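

Among the compounds shown here, the step in this assay is a 1.2-fold higher number from compound 1 to compound 3 (0.08 log units; within the scatter), and this is the first one-place comparison available at this position. It shows that the two groups on this carbonyl carbon cannot be told apart in this assay, even though phenyl, with 6 heavy atoms and a six-membered aromatic ring of carbon only, gives way to ethylamino, with 3 heavy atoms, no ring and 1 hydrogen-bond donor. So for this pair, the aromatic ring on the carbonyl carbon is not needed to keep the inhibition at the weak level seen, though no measurement here bears on why the two groups read alike.

For the compounds shown here, this single pair covers only two groups, both of them weak, so it remains open whether any group on this carbonyl carbon can produce a step beyond the scatter. A longer chain such as butylamino, a ring-bearing amine such as benzylamino, or a group ending in a carboxylic acid would test that question, and none of them appears among the compounds shown here.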